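Cyano to methoxy: working notes on compound 4

The compounds below may be only part of what the source reports. "The series", "measured", "known", "first", "only" and "open" are said of these compounds alone.

Measured in a functional assay on MCF7 cells (Homo sapiens) for cytotoxicity, read by CellTiter-Glo, with a stated time of 5 days; on this read-out higher numbers stand for weaker inhibition and lower numbers for stronger inhibition:
compound 1 `CC/C(=C(/c1ccc(/C=C/C(=O)O)cc1)c1ccc2[nH]ccc2c1)c1ccccc1`: 9 nM
compound 2 `CC/C(=C(/c1ccc(/C=C/C(=O)O)cc1)c1cccc2[nH]ncc12)c1ccccc1`: 21 nM
compound 3 `CC/C(=C(/c1ccc(/C=C/C(=O)O)cc1)c1ccc2[nH]ncc2c1)c1ccccc1C#N`: 12 nM

In this assay, compound 3 at 12 nM lies within the scatter of both other measured compounds, so it has no clear rank among them. The next compound is compound 4 `CC/C(=C(/c1ccc(/C=C/C(=O)O)cc1)c1ccc2[nH]ncc2c1)c1ccccc1OC`, and the change is methoxy in place of cyano on an aromatic carbon. Methoxy takes the place of cyano on an aromatic carbon, ortho to a large group.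

For the measured compounds named here, the only measured single-place step is a 2.3-fold higher number from compound 1 to compound 2 (0.37 log units; beyond the scatter). It is modest and lies at a different place from this change, so it bears only indirectly and gives a rough idea of step size in this small set. Going by the values given here, no measured pair isolates the cyano group or tests methoxy. No step beyond the scatter is therefore expected in this assay, in either direction. The estimated step is a 1.3-fold higher number from compound 3 to compound 4 (0.10 log units; within the scatter). Compound 4 is estimated at 15 nM, with an expected range of 6 nM to 40 nM.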

Compound 4, half-maximal inhibitory concentration: 25 nM
The estimate for compound 4 lay 1.7-fold (0.22 log units) below the measured number; measured number inside the range.
By their numbers in this assay, from the lowest: compounds 1, 3, 2 and 4 (each within the scatter of the next, the first and the last beyond it).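

In this assay, the change from 2-cyanophenyl to 2-methoxyphenyl gives a 2.1-fold higher number from compound 3 to compound 4 (0.32 log units; beyond the scatter), the first single-place step measured at this aromatic carbon, ortho to a large group. The step is modest but beyond the scatter, so this position does respond to the choice of group, even though nitrile and methoxy match in heavy-atom and hydrogen-bond acceptor counts. Nothing measured here bears on the origin of the step.

With only these two groups shown at this carbon, it remains open how a chlorine, a fluorine or an amine there would compare. Compound 1 and compound 2 differ from compound 4 in more than one place, so they cannot show what this ring would give with no group at this carbon.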